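Butyl to 3-(dimethylamino)propyl on the shared core

A few compounds are considered here, and "the series" means these few. Any claim that something is new, unique, unknown or untested is made for them only; others in the source may bear on it.

Measured so far, in a functional assay on DU-145 cells (Homo sapiens) for cytotoxicity, read by MTT assay, with a stated time of 2 days; a higher number here means a weaker inhibitor, a lower number a stronger inhibitor:
compound 1, `CCCCNc1nc(NCc2ccco2)c2ccccc2n1`: 4990 nM
compound 2, `CCCCNc1nc(NCc2ccco2)c2cc(F)ccc2n1`: 5910 nM

For the measured compounds named here, compound 1 and compound 2 give numbers that lie within the scatter of each other; the only measured step, a 1.2-fold higher number from compound 1 to compound 2 (0.07 log units; within the scatter), carries no weight. Compound 3, `CN(C)CCCNc1nc(NCc2ccco2)c2ccccc2n1`, keeps the core of compound 1 and changes the chain on the aromatic nitrogen: dimethylamino in place of methyl on a saturated chain carbon, three bonds along the chain from a nitrogen on an aromatic ring. Going by the values given here, no measured step touches this chain; the one step recorded concerns fluoro in place of hydrogen on an aromatic carbon and so says nothing about the change from compound 1 to compound 3. The series therefore gives no reason to expect a shift beyond the scatter, and the uncertainty is set wide. For compound 3 the expected step is a 1.0-fold higher number from compound 1 to compound 3 (0.00 log units; within the scatter). The estimate for compound 3 in this assay is 5000 nM, within 1500 nM to 16000 nM.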

Compound 3, half-maximal inhibitory concentration: 51000 nM
The estimate for compound 3 lay 10-fold (1.01 log units) below the measured number; measured number outside the range, above it.
By their numbers in this assay, from the lowest: compounds 1 and 2 (each within the scatter of the next); then compound 3.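

In this assay, for the compounds shown here, the chain on the shared core proves sensitive: butyl to 3-(dimethylamino)propyl gives a 10-fold higher number from compound 1 to compound 3 (1.01 log units; beyond the scatter) and so moves the compound towards weaker inhibition, whereas the only earlier step, on an aromatic carbon of the core, stayed within the scatter. Going by these compounds alone, this is the first change that separates two compounds, and it places dimethylamino on a saturated chain carbon, three bonds along the chain from a nitrogen on an aromatic ring. Nothing available bears on why the number rises at this position.

Open, from the compounds shown here alone, is whether a primary amine, a morpholine or a hydroxyl at the end of the same chain would give a number close to that of compound 1 or of compound 3. Also open, going by these compounds, is whether a longer chain carrying dimethylamino, or the same chain on the fluoro core of compound 2, would show a step of similar size.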